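This account rests on a few compounds, and the source may have more. Where it says the series, first, only, none or still open, it means among the compounds named here.

In a functional assay on HCT-116 cells (Homo sapiens) for antiproliferative activity, read by MTT assay, with a stated time of 72 h (a lower number here means a stronger inhibitor, a higher number a weaker inhibitor), compound 1 (`COc1ccc(N2C(=O)COc3ccc(-c4cnc(Cl)c(NS(=O)(=O)c5ccc(F)cc5)c4)cc32)cc1`) gives 30100 nM and compound 2 (`COc1ncc(-c2ccc3c(c2)N(C2CC2)C(=O)CO3)cc1NS(=O)(=O)c1ccc(F)cc1`) gives 24300 nM. Within the data shown here, these two numbers lie within the scatter of each other, so compound 2 stands level with the only other measured compound. Compound 3 (`O=C1COc2ccc(-c3cnc(Cl)c(NS(=O)(=O)c4ccc(F)cc4)c3)cc2N1C1CC1`) has not yet been measured. It departs from compound 2 in one place, with chloro in place of methoxy on an aromatic carbon, next to the ring nitrogen of a six-membered aromatic ring with 1 nitrogen: chloro in place of methoxy on an aromatic carbon. Among the measured compounds shown here, no step between measured compounds shows what such a change does in this assay, so there is no direct guide to its size. On this limited evidence, no step beyond the scatter is expected, in either direction. The expected step, a 1.0-fold lower number from compound 2 to compound 3 (0.01 log units; within the scatter), is therefore small. For compound 3, the estimated value is 24000 nM, with an expected range of 11000 nM to 50000 nM.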

Compound 3, half-maximal inhibitory concentration: 12400 nM
The estimate for compound 3 lay 1.9-fold (0.29 log units) above the measured number; low and high end bracket the measured number.
By their numbers in this assay, from the lowest: compounds 3, 2 and 1 (each within the scatter of the next, the first and the last beyond it).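

In this assay, among these compounds, the first reading of chloro in place of methoxy, on an aromatic carbon next to the ring nitrogen, is a 2.0-fold lower number from compound 2 to compound 3 (0.29 log units; within the scatter) and so resolves no difference between the two groups at this place. Among the compounds shown here, the first step beyond the scatter comes instead on the amide-type nitrogen in a ring, where cyclopropyl in place of 4-methoxyphenyl gives a 2.4-fold lower number from compound 1 to compound 3 (0.39 log units; beyond the scatter) and remains modest. Nothing measured here accounts for either step.

Going by these compounds, whether an amine or a nitrile on the same aromatic carbon would move the number beyond the scatter remains open. On these data alone, it is equally open how an ethyl group or a hydrogen in place of cyclopropyl on the amide-type nitrogen would compare.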